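The compounds below may be only part of what the source reports. "The series", "measured", "known", "first", "only" and "open" are said of these compounds alone.

In a functional assay on DU-145 cells (Homo sapiens) for inhibition, read by trypan blue exclusion, with a stated time of 96 h (a higher number here means a weaker inhibitor of growth, a lower number a stronger inhibitor of growth), compound 1 `O=C(/C(=C\c1ccc(O)c([N+](=O)[O-])c1)SCc1ccc(Cl)cc1)c1ccc(Cl)cc1` gives 10000 nM and compound 2 `O=C(/C(=C\c1ccc(O)c([N+](=O)[O-])c1)SCc1ccccc1Cl)c1ccc(Cl)cc1` gives 10000 nM, so the two stand level at the digits shown. Compound 3 `CN(C)c1ccc(/C=C(/SCc2ccccc2Cl)C(=O)c2ccc(Cl)cc2)cc1` reads > 100000 nM, which is a limit of the assay. Compound 4 `Cc1ccc(S/C(=C/c2ccc(O)c([N+](=O)[O-])c2)C(=O)c2ccc(Cl)cc2)cc1` is still unmeasured. It carries 4-methylphenyl in place of 2-chlorobenzyl on a sulfur. The closest measured evidence is the change on the same sulfur substituent, no change at the digits printed from compound 1 to compound 2 (within the scatter). The larger step of an at least 10-fold higher number from compound 2 to compound 3 (1.00 log units; beyond the scatter) replaces the 4-hydroxy-3-nitrophenyl group, which compound 4 retains, so it bears little here. Going by compound 2 and no change at the digits printed from compound 1 to compound 2 (within the scatter), no step beyond the scatter is expected in this assay, and no direction is favoured. The estimated change is no change at the digits printed from compound 2 to compound 4 (within the scatter). Compound 4 is estimated at 10000 nM, with an expected range of 3000 nM to 35000 nM.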

Compound 4, concentration for 50% growth inhibition: 10000 nM
Compound 4: the middle estimate sits on the measured number at the digits printed; low and high end bracket the measured number.
By their numbers in this assay, from the lowest: compounds 1, 2 and 4 (each within the scatter of the next). At a limit, above all of these: compound 3.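

In this assay, 4-methylphenyl in place of 2-chlorobenzyl on the sulfur gives no change at the digits printed from compound 2 to compound 4 (within the scatter), and 4-methylphenyl in place of 4-chlorobenzyl gives no change at the digits printed from compound 1 to compound 4 (within the scatter). The earlier pair varied only the chlorobenzyl group, whereas this position now also takes a group without chlorine, with no change in growth inhibition. Nothing measured here gives a reason for this sameness.

Going by these compounds, whether an amine, a carboxylic acid or a longer chain on this sulfur would read the same stays open. So does whether any group here can shift the number at all.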